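The compounds below may be only part of what the source reports. "The series", "measured", "known", "first", "only" and "open" are said of these compounds alone.

Among the compounds with values here, compound 2 `O=C(O)Cc1sc(Nc2ccccc2)nc1-c1ccc(F)cc1` is one of two compounds measured in an in vitro functional assay on HEK285-7 cells for antagonist activity at prostaglandin D2 receptor 2 (Homo sapiens), read by BRET and beta-arrestin recruitment; on this read-out lower numbers stand for stronger inhibition and higher numbers for weaker inhibition. In this assay compound 2 gives 1300 nM. Its companion compound 1 `O=C(O)Cc1sc(Nc2ccccc2)nc1-c1ccccc1` gives 1500 nM in this assay, and although the number for compound 2 is the smaller of the pair, the step of a 1.2-fold lower number from compound 1 to compound 2 (0.06 log units; within the scatter) is within the scatter, so the two compounds are not told apart by these data. Compound 3 `COc1ccc(-c2nc(Nc3ccccc3)sc2CC(=O)O)cc1` has not yet been measured. It differs from compound 2 by methoxy in place of fluoro on an aromatic carbon. Within the data shown here, only one measured step bears on this change: a 1.2-fold lower number from compound 1 to compound 2 (0.06 log units; within the scatter), which also altered a group on an aromatic carbon of that ring and moved the number only within the scatter. Among the measured compounds shown here, no measured pair exchanges fluoro for methoxy, so that particular change is untested here, and the account leans on the single small step seen. It therefore expects no step beyond the scatter, the estimated step being no change at the digits printed from compound 2 to compound 3 (within the scatter). Compound 3 is estimated to give 1300 nM in this assay, with an expected range from 500 nM to 3500 nM.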

Compound 3, half-maximal inhibitory concentration: 2400 nM
Beside the measured number, compound 3's estimate is 1.8-fold (0.27 log units) below it; the range from low to high includes it.
By their numbers in this assay, from the lowest: compounds 2, 1 and 3 (each within the scatter of the next).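

In this assay, the 4-fluorophenyl to 4-methoxyphenyl exchange gives a 1.8-fold higher number from compound 2 to compound 3 (0.27 log units; within the scatter), and placing methoxy where compound 1 carries hydrogen gives a 1.6-fold higher number from compound 1 to compound 3 (0.20 log units; within the scatter), so both steps stay within the scatter. This aromatic carbon, para to a large group, has now been tested with a substituent of two heavy atoms that brings a hydrogen-bond acceptor, as well as with the single fluorine atom, and hydrogen, fluoro and methoxy are not told apart by these data. No experimental evidence accompanies these numbers to explain them.

The compounds shown leave open whether a different kind of group on this carbon, such as an amine or a nitrile, would produce a step beyond the scatter. They also leave open whether the flat picture seen here extends to changes elsewhere in the shared core, since all three compounds differ only on this one carbon.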